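Opening the cyclohexenyl ring to a pentenyl chain

This account rests on a few compounds, and the source may have more. Where it says the series, first, only, none or still open, it means among the compounds named here.

Going by the values given here, compound 2 `CC(C(=O)NCc1ccc(C(F)(F)F)nc1C1=C[C@H](C)CCC1)c1ccc(NS(C)(=O)=O)c(F)c1` holds the lower of the two numbers measured so far in an assay on CHO cells for antagonist activity at transient receptor potential cation channel subfamily V member 1 (Homo sapiens), read by FLIPR and calcium flux; on this read-out higher numbers stand for weaker inhibition and lower numbers for stronger inhibition: compound 2 gives 0.1 nM, while compound 1 `CCCCCCc1nc(C(F)(F)F)ccc1CNC(=O)C(C)c1ccc(NS(C)(=O)=O)c(F)c1` gives 1.6 nM. Among the compounds with values here, the one step between measured compounds, a 16-fold lower number from compound 1 to compound 2 (1.20 log units; beyond the scatter), came from 3-methylcyclohex-1-en-1-yl in place of hexyl on an aromatic carbon. Compound 3 `CCC/C=C\c1nc(C(F)(F)F)ccc1CNC(=O)C(C)c1ccc(NS(C)(=O)=O)c(F)c1` moves partway back: pent-1-en-1-yl in place of 3-methylcyclohex-1-en-1-yl on an aromatic carbon. The entering group is an open chain with no ring, as hexyl in compound 1 is, yet it keeps one double bond outside aromatic rings, as the ring of compound 2 does. The change is therefore expected to undo only part of a 16-fold lower number from compound 1 to compound 2 (1.20 log units; beyond the scatter), and a moderately higher number in this assay is expected, a 5.0-fold higher number from compound 2 to compound 3 (0.70 log units; beyond the scatter). Compound 3 is estimated at 0.5 nM in this assay, with a range from 0.15 nM to 2 nM.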

Compound 3, inhibition constant: 2.1 nM
The estimate for compound 3 lay 4.2-fold (0.62 log units) below the measured number; measured number outside the range, above it.
By their numbers in this assay, from the lowest: compound 2; then compounds 1 and 3 (each within the scatter of the next).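

In this assay, pent-1-en-1-yl in place of 3-methylcyclohex-1-en-1-yl gives a 21-fold higher number from compound 2 to compound 3 (1.32 log units; beyond the scatter) on this carbon next to the ring nitrogen, so one double bond outside aromatic rings is not enough to keep the low number of compound 2. Pent-1-en-1-yl in place of hexyl gives a 1.3-fold higher number from compound 1 to compound 3 (0.12 log units; within the scatter) and stays within the scatter, so the two open chains cannot be told apart here, and of the three groups only the ring-bearing one stands apart. Nothing at hand accounts for the difference between the ring and the open chains.

Still open, going by these compounds, is whether the ring itself, its methyl group or its defined stereocentre goes with the low number of compound 2. Unsubstituted cyclohex-1-en-1-yl, the opposite methyl stereoisomer and saturated cyclohexyl on the same carbon would separate these.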